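A few compounds are considered here, and "the series" means these few. Any claim that something is new, unique, unknown or untested is made for them only; others in the source may bear on it.

Three compounds sharing a long chain capped by an amide have been tested in a functional assay on HCT-116 cells (Homo sapiens) for inhibition, read by colorimetric assay, with a stated time of 3 days; on this read-out lower numbers stand for stronger inhibition and higher numbers for weaker inhibition. Compound 1 `NC(=O)C(=O)NCCCCC(=O)Nc1ccccc1` is the starting point of this account. In this assay compound 1 gives only a limit of the assay, > 100000 nM, so no number is known for it. Where compound 1 stands is thus described only by the limit of > 100000 nM in this assay, at which 1 of the 3 values shown sits. Compound 2 `COc1ccc2sc(NC(=O)CCCCCCNC(=O)C(O)(O)C(F)(F)F)nc2c1` and compound 3 `O=C(CCCCCCNC(=O)C(O)(O)C(F)(F)F)Nc1ccc(F)cc1F` are built differently at their ends. In this assay compound 2 gives 2180 nM, and compound 3 gives 18500 nM. Within the data shown here, since no two measured compounds differ in a single place, no measured step is available to lean on.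

Compound 4 `CC(=O)C(=O)NCCCCC(=O)Nc1ccccc1` has not yet been measured. It differs from compound 1 in one place: methyl in place of amino on a carbonyl carbon. With nothing measured to set against it, I expect compound 4 to stay weak, and the step of a number no higher from compound 1 to compound 4 (the limit leaves the size open) is estimated to be small, within the scatter. Compound 4 is estimated at 100000 nM, with a range from 30000 nM to 300000 nM.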

Compound 4, half-maximal inhibitory concentration: > 100000 nM
Compound 4: no number, only a limit; the forecaster's own chance of this, stated with the estimate: 60%; the middle value lies on the limit itself.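

In this assay compound 4 gives > 100000 nM, which is a limit of the assay and not a number. Among these compounds, compound 1 also stands at a limit, and no step between compound 1 and compound 4 can be read. The compounds shown leave open whether methyl in place of amino on a carbonyl carbon changes inhibition at all.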